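A phenoxy group in place of the carbamoyloxy chain

A few compounds are considered here, and "the series" means these few. Any claim that something is new, unique, unknown or untested is made for them only; others in the source may bear on it.

For the measured compounds named here, compound 1 `CC1=C(N2CC2)C(=O)C(CC(C)OC(N)=O)=C(N2CC2)C1=O` gives 5.86 in a functional assay on L1210 cells (Mus musculus), with a stated time of 1 days (on this read-out higher numbers stand for higher potency (the scale is a negative logarithm) and lower numbers for lower potency), the second highest of the three numbers known. Compound 3 `CC1=C(N2CC2)C(=O)C(C(C)COC(N)=O)=C(N2CC2)C1=O` gives 5.93, and the difference is a number 0.07 log units higher from compound 1 to compound 3 (within the scatter). Compound 2 `CC1=C(N2CC2)C(=O)C(C(C)C)=C(N2CC2)C1=O` gives 4.96; the step is a number 0.90 log units lower from compound 1 to compound 2 (beyond the scatter). Compound 4 `CC1=C(N2CC2)C(=O)C(COc2ccccc2)=C(N2CC2)C1=O` carries a group of 7 heavy atoms (6 carbon, 1 oxygen; one six-membered aromatic ring of carbon only) in place of a group of 6 heavy atoms (3 carbon, 1 nitrogen, 2 oxygen; no ring), on a saturated chain carbon bound to a double-bonded ring carbon. The measured step that bears on this is the gain of a carbamoyloxy group, a number 0.97 log units higher from compound 2 to compound 3 (beyond the scatter), and its mirror in the drop to compound 2; the phenoxy group itself has no measured counterpart among these compounds. The expected step is therefore a number 0.76 log units lower from compound 1 to compound 4 (beyond the scatter), landing close to compound 2. For compound 4 the estimate is 5.1, with a range of 4.5 to 5.8.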

Compound 4, logarithm of the reciprocal of the active concentration, log(1/C): 4.68
For compound 4 the middle estimate is 0.42 log units above the measured one, and the stated range covers the measured number.
By their numbers in this assay, from the lowest: compounds 4 and 2 (each within the scatter of the next); then compounds 1 and 3 (each within the scatter of the next).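

In this assay, replacing the chain with phenoxy on this saturated chain carbon gives a number 1.18 log units lower from compound 1 to compound 4 (beyond the scatter), although the entering group is of similar size by heavy-atom count. Compound 4 lies within the scatter of compound 2, so at this position an ether-linked phenyl ring does not preserve the higher number seen with the carbamoyloxy chain. Nothing measured here accounts for this drop. The compounds shown leave open whether a hydroxyl, an acetoxy group or a primary amine on this chain would match compound 1.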